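A few compounds are considered here, and "the series" means these few. Any claim that something is new, unique, unknown or untested is made for them only; others in the source may bear on it.

Of the compounds shown here, three have been measured in an assay on isolated protein for inhibition of DNA topoisomerase 1 (Homo sapiens), with a stated time of 15 min; a higher number here means a weaker inhibitor, a lower number a stronger inhibitor. Compound 1 `O=C(O)c1cn(Cc2ccc(-n3cccn3)cc2)c2cc(NC[C@H]3CCNC3)c(F)cc2c1=O` gives 187000 nM. Compound 2 `CNCCCNc1c(F)cc2c(=O)c(C(=O)O)cn(Cc3ccc(-c4ccccc4)cc3)c2c1OC` gives 101000 nM, and compound 3 `CNCCCNc1cc2c(cc1F)c(=O)c(C(=O)O)cn2Cc1ccc(-c2ccccc2)cc1` gives 63600 nM. The numbers of compound 1 and compound 3 both sit within the scatter of the number of compound 2, so no order among the three can be claimed. Within the data shown here, the only single-point step recorded is a 1.6-fold lower number from compound 2 to compound 3 (0.20 log units; within the scatter), hydrogen in place of methoxy on an aromatic carbon, and it stays within the scatter.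

Compound 4 `CNCCCCNc1c(F)cc2c(=O)c(C(=O)O)cn(Cc3ccc(-c4ccccc4)cc3)c2c1OC` differs from compound 2 by (methylamino)methyl in place of methylamino on a saturated chain carbon, three bonds along the chain from a nitrogen on an aromatic ring. Among the measured compounds shown here, no measured step touches this chain, so none of them bears on the change directly; the one recorded step concerns another position and was itself within the scatter. On this footing no change beyond the scatter is expected in this assay, and the expected step is a 1.0-fold lower number from compound 2 to compound 4 (0.00 log units; within the scatter). Compound 4 is accordingly estimated at 100000 nM, within a range from 40000 nM to 250000 nM.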

Compound 4, half-maximal inhibitory concentration: > 200000 nM
Compound 4: no number, only a limit; the forecaster's own chance of this, stated with the estimate: 10%; middle value at least 2.0-fold (0.30 log units) from the limit.
By their numbers in this assay, from the lowest: compounds 3, 2 and 1 (each within the scatter of the next, the first and the last beyond it). At a limit, above all of these: compound 4.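

Among these compounds, the change from methylamino to (methylamino)methyl, on a saturated chain carbon, three bonds along the chain from a nitrogen on an aromatic ring, is the first change on this chain to be measured, and in this assay it gives an at least 1.9-fold higher number from compound 2 to compound 4 (0.29 log units; that floor lies within the scatter). The reading for compound 4 is a limit of the assay and not a number: the limit of > 200000 nM in this assay, at which 1 of the 4 values shown sits. From the compounds shown here alone, the step is therefore only a floor, and it shows that this position does not gain from the added carbon in this assay, while the true size of the change remains unknown.

Going by these compounds, how far the number of compound 4 lies past the limit remains open. So does the outcome of a 2-(methylamino)ethyl chain, a primary amine or a dimethylamino group at this position.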